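Toward a Smaller Side Chain in HepG2 Cytotoxicity

This account rests on a few compounds, and the source may have more. Where it says the series, first, only, none or still open, it means among the compounds named here.

Measured in a functional assay on HepG2 cells (Homo sapiens) for cytotoxicity, read by MTT assay, with a stated time of 72 h; on this read-out higher numbers stand for weaker inhibition and lower numbers for stronger inhibition:
- Compound 1 `Cc1ccc(-c2nc3cc(NC(=O)CCN4CCN(C)CC4)ccc3[nH]2)cc1`: > 50000 nM (a limit of the assay, not a number)
- Compound 2 `CCN1CCN(CCC(=O)Nc2ccc3[nH]c(-c4ccc(C)cc4)nc3c2)CC1`: 14600 nM

Within the data shown here, compound 2, at 14600 nM, holds the only true number so far. The next molecule, compound 3 `Cc1ccc(-c2nc3cc(NC(=O)CN4CCCCC4)ccc3[nH]2)cc1`, differs from it in one place: piperidin-1-yl in place of (4-ethylpiperazin-1-yl)methyl on a saturated chain carbon bound to a carbonyl carbon. Among the measured compounds shown here, only one measured step bears on this change. It is an at least 3.4-fold lower number from compound 1 to compound 2 (0.53 log units; beyond the scatter), which came from a methyl in place of hydrogen on a saturated chain carbon bound to an amine nitrogen in a ring. That small edit moved the reading beyond the scatter, and the group it touched leaves altogether in compound 3. One step is thin support, but a modest move toward weaker inhibition in this assay seems likely. The expected step is a 1.9-fold higher number from compound 2 to compound 3 (0.28 log units; within the scatter). For compound 3 the estimated value is 28000 nM, with an expected range from 10000 nM to 70000 nM.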

Compound 3, half-maximal inhibitory concentration: > 50000 nM
Compound 3: only a limit was reported; the forecaster's own chance of this, stated with the estimate: 35%; middle value at least 1.7-fold (0.25 log units) away from the limit.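

In this assay, putting piperidin-1-yl in place of (4-ethylpiperazin-1-yl)methyl on a saturated chain carbon bound to a carbonyl carbon gives an at least 3.4-fold higher number from compound 2 to compound 3 (0.53 log units; beyond the scatter), so replacing this whole group moves the reading beyond the scatter, which the earlier methyl edit on the ring alone could not show. Compound 3 gives > 50000 nM, which is a limit of the assay and not a number. The step from compound 1 to compound 3 cannot be read, and compound 2 alone keeps a true number: the limit of > 50000 nM in this assay, at which 2 of the 3 values shown sit.

The change removes the ethyl group, a ring nitrogen and a chain carbon all at once, and the compounds shown do not separate these parts. On these data alone, whether a morpholine ring or an open-chain dimethylamine at this place would give a measurable number also stays open.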